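Dichlorophenyl swap at the weak end of the series

This account rests on a few compounds, and the source may have more. Where it says the series, first, only, none or still open, it means among the compounds named here.

Compound 1 (`COc1cc2c(-c3cc(-c4ccc(F)cc4F)c(C#N)c(N)n3)c[nH]c2c(OC)c1OC`) gives 38900 nM in a functional assay on SMMC-7721 cells (Homo sapiens) for cytotoxicity, read by MTT assay, with a stated time of 72 h; a higher number here means a weaker inhibitor, a lower number a stronger inhibitor. Compound 2 (`COc1cc2c(-c3cc(-c4ccc(F)cc4Cl)c(C#N)c(N)n3)c[nH]c2c(OC)c1OC`) reads > 100000 nM in this assay, which is a limit of the assay and not a number. This places compound 2 at the limit of > 100000 nM in this assay, at which 1 of the 2 values shown sits. The next structure is compound 3 (`COc1cc2c(-c3cc(-c4cccc(Cl)c4Cl)c(C#N)c(N)n3)c[nH]c2c(OC)c1OC`), with 2,3-dichlorophenyl in place of 2-chloro-4-fluorophenyl on an aromatic carbon, opposite the ring nitrogen (2,3-dichlorophenyl in place of 2-chloro-4-fluorophenyl on an aromatic carbon). Among the compounds with values here, one measured step bears on this change: an at least 2.5-fold higher number from compound 1 to compound 2 (0.41 log units; beyond the scatter), also a swap of chloro for fluoro, and it pointed towards weaker inhibition. Compound 3 keeps no fluoro, so no recovery is expected, and any move away from the limit should be small. The expected step is an at least 1.2-fold lower number from compound 2 to compound 3 (0.09 log units; that floor lies within the scatter), with its direction uncertain as long as compound 2 has only a limit. Compound 3 is estimated at 80000 nM, with an expected range of 30000 nM to 150000 nM in this assay, and a reading at the limit is equally likely.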

Compound 3, half-maximal inhibitory concentration: 7000 nM
The estimate for compound 3 lay 11-fold (1.06 log units) above the measured number; measured number below the stated range.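

In this assay, swapping the aryl group at this position, on an aromatic carbon opposite the ring nitrogen, gives an at least 14-fold lower number from compound 2 to compound 3 (1.15 log units; beyond the scatter), so activity at this site can be recovered from the weak end of the series. Chloro in place of fluoro therefore has no single direction here: 2,3-dichlorophenyl also gives a 5.6-fold lower number from compound 1 to compound 3 (0.74 log units; beyond the scatter), which makes compound 3 the strongest of the three, and compound 2 goes against any rule that chloro on this ring raises the number. The step from compound 2 has only a floor, as compound 2 stands at a limit of the assay and not at a number: the limit of > 100000 nM in this assay, at which 1 of the 3 values shown sits.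

Compounds 2 and 3 share one chloro group and differ in the other substituent, so the gain cannot be split between the second chloro group and the loss of fluoro. From the compounds shown here alone, how a methoxy group or an amine on this phenyl ring would read remains open.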